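The source may hold more compounds than are shown below. What is called first, only, known or untested is meant among the compounds shown, and "the series" means these compounds.

Compounds measured so far:
Compound 1 `Cc1ccc2[nH]c(=O)c(-c3nc4cc([N+](=O)[O-])ccc4[nH]3)cc2c1` — in a functional assay on SK-OV-3 cells (Homo sapiens) for cytotoxicity, read by MTT assay, with a stated time of 48 h (on this read-out lower numbers stand for stronger inhibition and higher numbers for weaker inhibition), compound 1 gives > 100000 nM, which is a limit of the assay rather than a number.
Compound 2 `Cc1ccc2[nH]c(=O)c(-c3nc4ccccc4[nH]3)cc2c1` — compound 2 gives > 100000 nM, likewise a limit.
Compound 3 `Cc1ccc2[nH]c(=O)c(-c3nc4cc(Cl)ccc4[nH]3)cc2c1` — compound 3 gives 33000 nM.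

Compound 1 thus stands at the assay limit with no number of its own (the limit of > 100000 nM in this assay, at which 2 of the 3 values shown sit). Compound 4 `COc1ccc2[nH]c(=O)c(-c3nc4cc([N+](=O)[O-])ccc4[nH]3)cc2c1` differs from it by methoxy in place of methyl on an aromatic carbon. The measured steps all concern the other ring of the shared core: an at least 3.0-fold lower number from compound 1 to compound 3 (0.48 log units; beyond the scatter) and an at least 3.0-fold lower number from compound 2 to compound 3 (0.48 log units; beyond the scatter), while a step that the two limits leave unreadable from compound 1 to compound 2. Within the data shown here, none touches the position of the methyl, so no measured step bears directly on this change. For compound 4 the expected step is a step that the limit leaves unreadable from compound 1 to compound 4, nothing beyond the scatter. Compound 4 is therefore estimated at 150000 nM, within 50000 nM to 500000 nM, and most likely reported again only as a limit.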

Compound 4, half-maximal inhibitory concentration: > 100000 nM
Compound 4 ended at the assay's limit (the forecaster's own chance of this, stated with the estimate: 80%); the middle value is on the limit's open side.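

Compound 1 and compound 4 both end at a limit rather than a number, so the step between them cannot be read: the limit of > 100000 nM in this assay, at which 3 of the 4 values shown sit.

On these data alone, whether methoxy in place of methyl changes the potency of this nitro-bearing pair at all remains open.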